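The source may hold more compounds than are shown below. What is called first, only, known or untested is meant among the compounds shown, and "the series" means these compounds.

Measured in a functional assay on K562 cells (Homo sapiens), read by MTT assay, with a stated time of 72 h; on this read-out lower numbers stand for stronger inhibition and higher numbers for weaker inhibition:
- Compound 1 `Nc1nc(N)c2c(-c3ccsc3)cn([C@@H]3O[C@H](CO)[C@@H](O)[C@H]3O)c2n1`: > 20000 nM (a limit)
- Compound 2 `COc1nc(N)nc2c1c(-c1cccs1)cn2[C@@H]1O[C@H](CO)[C@@H](O)[C@H]1O`: > 20000 nM (a limit)

Neither compound has a numerical value. In this assay compound 2 gives > 20000 nM, which is a limit and not a number. Both compounds therefore stand at the limit of > 20000 nM in this assay, at which 2 of the 2 values shown sit.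

Compound 3 `COc1nc(N)nc2c1c(-c1ccsc1)cn2[C@@H]1O[C@H](CO)[C@@H](O)[C@H]1O` has the same atoms as compound 2, joined differently, with thiophen-3-yl in place of thiophen-2-yl on an aromatic carbon.

Within the data shown here, no measured step shows what such an exchange does in this assay. With both measured compounds at the limit, no change beyond the usual scatter is expected. The expected step that the limit leaves unreadable from compound 2 to compound 3 is accordingly small, and the assay will probably report only a limit again. In this assay the estimate for compound 3 is 25000 nM, expected to lie between 8000 nM and 50000 nM.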

Compound 3, half-maximal inhibitory concentration: > 20000 nM
Compound 3 ended at the assay's limit; the forecaster's own chance of this, stated with the estimate: 85%; the middle value lies beyond the limit too.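

In this assay, among these compounds, compound 3 gives > 20000 nM, which is a limit, so no step from compound 1 or compound 2 to compound 3 can be read. The compounds shown leave open whether either exchange alters inhibition at all, since all three stand at one limit: the limit of > 20000 nM in this assay, at which 3 of the 3 values shown sit.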